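Moving the Amide Substituent: What to Expect for Compound 4

This account rests on a few compounds, and the source may have more. Where it says the series, first, only, none or still open, it means among the compounds named here.

Of the compounds shown here, three with a shared core have been measured in a functional assay on MCF7 cells (Homo sapiens) for inhibition, read by MTT assay; on this read-out higher numbers stand for weaker inhibition of growth and lower numbers for stronger inhibition of growth. Compound 1 `COc1cc2oc(-c3cccc(NC(=O)c4ccc(Br)cc4)c3)cc(=O)c2c(OC)c1OC` gives 9650 nM and stands second highest of the three numbers. Compound 3 `COc1cc2oc(-c3cccc(NC(=O)c4ccc(C)cc4)c3)cc(=O)c2c(OC)c1OC` gives 8320 nM, and the step of a 1.2-fold lower number from compound 1 to compound 3 (0.06 log units; within the scatter) lies within the scatter, so the two cannot be told apart on this read-out. Compound 2 `COc1cc2oc(-c3cccc(NC(=O)c4ccccc4Br)c3)cc(=O)c2c(OC)c1OC` gives 55000 nM, and the step of a 5.7-fold higher number from compound 1 to compound 2 (0.76 log units; beyond the scatter) shows a modest loss of growth inhibition when the 4-bromophenyl becomes a 2-bromophenyl.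

Compound 4 `COc1ccccc1C(=O)Nc1cccc(-c2cc(=O)c3c(OC)c(OC)c(OC)cc3o2)c1` is not yet measured. It differs from compound 1 by 2-methoxyphenyl in place of 4-bromophenyl on a carbonyl carbon. The step that bears on this is a 5.7-fold higher number from compound 1 to compound 2 (0.76 log units; beyond the scatter), since it too exchanges a 4-bromophenyl for a 2-bromophenyl; the step of a 1.2-fold lower number from compound 1 to compound 3 (0.06 log units; within the scatter) adds that swapping bromo for methyl changed little. On that basis a modest rise in the number, meaning weaker inhibition, is expected for compound 4, the step being a 3.1-fold higher number from compound 1 to compound 4 (0.49 log units; beyond the scatter). The estimate for compound 4 in this assay is 30000 nM, with a range from 9000 nM to 90000 nM.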

Compound 4, concentration for 50% growth inhibition: 15300 nM
The estimate for compound 4 lay 2.0-fold (0.29 log units) above the measured number, and the stated range covers the measured number.
By their numbers in this assay, from the lowest: compounds 3, 1 and 4 (each within the scatter of the next); then compound 2.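

In this assay, the 2-methoxyphenyl amide of compound 4 cannot be told apart from the 4-bromophenyl amide (a 1.6-fold higher number from compound 1 to compound 4 (0.20 log units; within the scatter)) or from the 4-methylphenyl amide (a 1.8-fold higher number from compound 3 to compound 4 (0.26 log units; within the scatter)). Methoxy in place of bromo on the same ring gives a real change (a 3.6-fold lower number from compound 2 to compound 4 (0.56 log units; beyond the scatter)), so among these four compounds the weak result belongs to compound 2 alone, and a 2-substituted phenyl does not always mean a clear loss of growth inhibition. Nothing available explains this difference between methoxy and bromo.

Two groups of this kind on the 2-substituted ring are too few to show what sets the result there. From the compounds shown here alone, how an amine, a carboxylic acid or a longer chain on this phenyl ring would read remains open.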